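The source may hold more compounds than are shown below. What is called first, only, known or untested is meant among the compounds shown, and "the series" means these compounds.

Of the compounds shown here, two have been measured in a functional assay on cells (T-cell, Mus musculus, strain BALB/c) for inhibition, read by MTT assay, with stated times of 24 h and 72 h; a lower number here means a stronger inhibitor, a higher number a weaker inhibitor. Compound 1 `COc1cc(-c2nnc(SCc3cccc(Br)c3)o2)ccc1O` gives 48100 nM in this assay. Compound 2 `COc1cc(-c2nnc(SCc3ccccc3[N+](=O)[O-])o2)ccc1O` gives 9600 nM in this assay, the lowest of the two numbers, and its gap to compound 1 lies beyond the usual scatter. Compound 3 `COc1cc(-c2nnc(SCc3ccccc3F)o2)ccc1O` differs from compound 2 in one place: fluoro in place of nitro on an aromatic carbon. Among the measured compounds shown here, no measured pair shows this change, so its size is unknown. Compound 3 is expected to give a higher number than compound 2, a weakening step estimated at a 2.6-fold higher number from compound 2 to compound 3 (0.42 log units; beyond the scatter). The estimate for compound 3 is 25000 nM, with a range from 8000 nM to 80000 nM.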

Compound 3, half-maximal inhibitory concentration: 5790 nM
Estimate against measurement, compound 3: 4.3-fold (0.64 log units) above; measured number below the stated range.
By their numbers in this assay, from the lowest: compounds 3 and 2 (each within the scatter of the next); then compound 1.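

In this assay, fluoro in place of nitro on this aromatic carbon, ortho to a large group, gives a 1.7-fold lower number from compound 2 to compound 3 (0.22 log units; within the scatter), so the two groups are not told apart here. 2-Fluorophenyl in place of 3-bromophenyl on the saturated chain carbon bound to a sulfur gives an 8.3-fold lower number from compound 1 to compound 3 (0.92 log units; beyond the scatter), but this step exchanges both the halogen and its place on the ring, and the two are not separated. Nothing measured accounts for either step. Still open, from the compounds shown here alone, is how an amine or a carboxylic acid on this aromatic carbon would read in this assay, and how 2-bromophenyl on the same chain carbon would compare with 2-fluorophenyl.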